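This account rests on a few compounds, and the source may have more. Where it says the series, first, only, none or still open, it means among the compounds named here.

Compound 2 `CN1CCN(CC(=O)Nc2ccc(-c3nc(-c4ccccc4)c(-c4ccccc4)n3C)cc2)CC1` gives 49.1% in a functional assay on HT-29 cells (Homo sapiens) for cytotoxicity, read by MTT assay, with a stated time of 24 h, tested at 32 ug/mL; a higher number here means a stronger effect of the compound at the concentration tested, a lower number a weaker effect; compound 1 `Cn1ccnc1SCC(=O)Nc1ccc(-c2nc(-c3ccccc3)c(-c3ccccc3)n2C)cc1` gives 41.1%, and the two numbers lie within the scatter of each other, so neither stands apart. Within the data shown here, the only measured step, a number 8 percentage points higher from compound 1 to compound 2 (within the scatter), concerns a different part of the chain and is itself within the scatter. Compound 3 `COc1ccc(CN2CCN(CC(=O)Nc3ccc(-c4nc(-c5ccccc5)c(-c5ccccc5)n4C)cc3)CC2)cc1` differs from compound 2 by 4-methoxyphenyl in place of hydrogen on a saturated chain carbon bound to an amine nitrogen in a ring. Among the measured compounds shown here, no measured step covers an addition of this kind, so no shift beyond the scatter is expected in this assay. The step expected is a number 0.9 percentage points higher from compound 2 to compound 3 (within the scatter), nothing beyond the scatter. Compound 3 is estimated at 50%, within 30% to 70%.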

Compound 3, a percentage reported as activity, at one concentration (the size of the read-out at that concentration, not a potency): 29.9%
Beside the measured number, compound 3's estimate is 20.1 percentage points above it; the whole stated range lies above it.
By their numbers in this assay, from the lowest: compound 3; then compounds 1 and 2 (each within the scatter of the next).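

In this assay, among these compounds, the change from methyl to 4-methoxybenzyl brings a number 19.2 percentage points lower from compound 2 to compound 3 (beyond the scatter), the only step so far beyond the scatter. Among the compounds shown here, this position therefore affects the read-out, whereas the one earlier change, on the saturated chain carbon bound to a carbonyl carbon, stayed within the scatter. The direction of this step is downward, with 4-methoxyphenyl in place of hydrogen.

On these data alone, whether the drop belongs to the aromatic ring or to its methoxy group stays open, and benzyl, 4-hydroxybenzyl or ethyl at this position would help separate these readings. No available evidence accounts for the drop.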